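Swapping the distal aryl group on a GPR88 agonist scaffold

The compounds below may be only part of what the source reports. "The series", "measured", "known", "first", "only" and "open" are said of these compounds alone.

Measured so far in a functional assay for agonist activity at G protein-coupled receptor 88 (Homo sapiens), read by HTRF and cAMP accumulation; on this read-out higher numbers stand for an effect only at larger amounts of compound and lower numbers for an effect already at smaller amounts:
compound 1 `CC(C)C[C@H](N)CN(C(=O)[C@@H]1C[C@H]1c1ccccc1)c1ccc(-c2ccncc2)cc1` gives 13000 nM
compound 2 `COc1cccc(-c2ccc(N(C[C@@H](N)CC(C)C)C(=O)[C@@H]3C[C@H]3c3ccccc3)cc2)c1` gives 1100 nM

Within the data shown here, compound 2 stands lowest of the two numbers; its nearest neighbour is compound 1, and the single measured step, a 12-fold lower number from compound 1 to compound 2 (1.07 log units; beyond the scatter), is large. Compound 3 `CC(C)C[C@H](N)CN(C(=O)[C@@H]1C[C@H]1c1ccccc1)c1ccc(-c2ccc(C#N)cc2)cc1` has not yet been measured. It differs from compound 2 by 4-cyanophenyl in place of 3-methoxyphenyl on an aromatic carbon. Among the measured compounds shown here, the only step that bears on this change is a 12-fold lower number from compound 1 to compound 2 (1.07 log units; beyond the scatter), which exchanged groups at the same position but with a different pair of groups, so it guides the expectation only loosely. The entering 4-cyanophenyl shares with the pyridin-4-yl of compound 1 a nitrogen hydrogen-bond acceptor, and compound 1 sits well above compound 2. Compound 3 is therefore expected to lose some ground against compound 2, with an estimated step of a 3.2-fold higher number from compound 2 to compound 3 (0.50 log units; beyond the scatter). The estimate for compound 3 is 3500 nM, within a range of 900 nM to 13000 nM.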

Compound 3, half-maximal effective concentration: 670 nM
Compound 3: the middle estimate sits 5.2-fold (0.72 log units) above what was measured; the whole stated range lies above it.
By their numbers in this assay, from the lowest: compounds 3 and 2 (each within the scatter of the next); then compound 1.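

In this assay, the change from 3-methoxyphenyl to 4-cyanophenyl gives a 1.6-fold lower number from compound 2 to compound 3 (0.22 log units; within the scatter), so these two quite different substituted rings cannot be told apart at this position. Measured against the pyridin-4-yl group, 4-cyanophenyl gives a 19-fold lower number from compound 1 to compound 3 (1.29 log units; beyond the scatter), which shows that the large step first seen with compound 2 is not tied to the 3-methoxyphenyl group and also appears with a second ring of carbon only. The data include no measurement that explains why compound 1 stands apart from compound 2 and compound 3.

Going by these compounds, it remains open whether an unsubstituted phenyl ring would stay at this level, which would show whether the methoxy and nitrile groups matter at all. On these data alone, it is also open whether an amine or a carboxylic acid in place of the nitrile would keep it there.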